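The source may hold more compounds than are shown below. What is called first, only, known or untested is meant among the compounds shown, and "the series" means these compounds.

In a functional assay on MOLT-4 cells (Homo sapiens) for cytotoxicity, with a stated time of 72 h (on this read-out higher numbers stand for weaker inhibition and lower numbers for stronger inhibition), three compounds give a footing for the step. Compound 1 `CN(C)c1ccc(/C=C2\CCC/C(=C\c3ccccc3[N+](=O)[O-])C2=O)cc1` gives 122000 nM in this assay. Compound 2 `O=C1CCCC/C1=C\c1ccc([N+](=O)[O-])cc1` gives 13900 nM in this assay. Compound 3 `O=C1/C(=C/c2ccc(Cl)cc2)CCC/C1=C\c1ccc([N+](=O)[O-])cc1` gives 9120 nM in this assay. Among these numbers compound 3 holds the lowest, but compound 2 sits within the usual scatter of it, so the two cannot be ranked; only compound 1 lies clearly beyond the scatter, with the higher number. Compound 4 `O=C1/C(=C/c2ccccc2)CCC/C1=C\c1ccc([N+](=O)[O-])cc1` has not yet been measured. It differs from compound 3 in one place: hydrogen in place of chloro on an aromatic carbon. Among the compounds with values here, no measured pair shows this change on its own, so its size rests on judgement alone. The loss of a single chlorine at the far end of one arylidene arm is a small edit, and the expected step from compound 3 to compound 4 is a 1.4-fold higher number from compound 3 to compound 4 (0.15 log units; within the scatter), a shift not beyond the scatter. For compound 4 in this assay the estimate is 13000 nM, with a range from 5000 nM to 35000 nM.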

Compound 4, half-maximal inhibitory concentration: 8350 nM
For compound 4 the middle estimate is 1.6-fold (0.19 log units) above the measured one; the range from low to high includes it.
By their numbers in this assay, from the lowest: compounds 4, 3 and 2 (each within the scatter of the next); then compound 1.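

Going from 4-chlorophenyl to phenyl gives a 1.1-fold lower number from compound 3 to compound 4 (0.04 log units; within the scatter) in this assay, so chloro and hydrogen at this place on the aromatic ring cannot be told apart on this read-out. Within the data shown here, this is the first pair here in which one change stands alone, and it shows that the chlorine is not needed for compound 4 to reach a number level with that of compound 3. Nothing further on hand bears on this result.

As far as these compounds go, whether a different group at this same place, such as methoxy, a carboxylic acid or a longer carbon chain, would move the number beyond the scatter remains open. Also open, from the compounds shown here alone, is whether swapping chloro for hydrogen would be as quiet in a compound with another group on the second arylidene arm in place of the nitro group.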